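Fluoro-Methylphenyl Variant of Compound 2: Expected Clearance

The compounds below may be only part of what the source reports. "The series", "measured", "known", "first", "only" and "open" are said of these compounds alone.

In an in vivo ADME assay on the whole organism (strain Sprague-Dawley) for pharmacokinetics, with Rattus norvegicus as the target, at a dose of 2 mg/kg by the intravenous route (a lower number here means slower removal, a higher number faster removal of the compound), compound 2 `Cc1cnc(C(=O)NC2CC2)cc1-c1cc2cnnc(-c3ccccc3Cl)c2n(C)c1=O` gives 13.2 mL/min/kg, the lowest of the two values recorded, while compound 1 `Cc1cnc(C(=O)NC2CC2)cc1-c1cc2cnnc(-c3ccccc3C)c2n(C)c1=O` gives 81.8 mL/min/kg. Going by the values given here, the single measured step, a 6.2-fold lower number from compound 1 to compound 2 (0.79 log units; beyond the scatter), is what separates them. Compound 3 `Cc1cnc(C(=O)NC2CC2)cc1-c1cc2cnnc(-c3ccc(F)cc3C)c2n(C)c1=O` carries 4-fluoro-2-methylphenyl in place of 2-chlorophenyl on an aromatic carbon. Among the compounds with values here, this change brings back the methyl found in compound 1 and adds a fluorine that no measured step covers, so the number is expected to rise partway back toward that of compound 1. The estimated step is a 3.0-fold higher number from compound 2 to compound 3 (0.48 log units; beyond the scatter). Compound 3 is therefore expected to show 40 mL/min/kg, within 15 mL/min/kg to 90 mL/min/kg.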

Compound 3, clearance: 30.7 mL/min/kg
Compound 3: the middle estimate sits 1.3-fold (0.11 log units) above what was measured, within the range that was stated.
By their numbers in this assay, from the lowest: compound 2; then compound 3; then compound 1.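

In this assay, fluoro in place of hydrogen on an aromatic carbon gives a 2.7-fold lower number from compound 1 to compound 3 (0.43 log units; beyond the scatter), so the methyl-bearing group need not stay at the high number of compound 1. Even so, 4-fluoro-2-methylphenyl in place of 2-chlorophenyl gives a 2.3-fold higher number from compound 2 to compound 3 (0.37 log units; beyond the scatter), so the fluorine closes only part of the gap between the methyl and chloro compounds. No measurement at hand accounts for either step.

As far as these compounds go, it remains open whether a fluorine on the 2-chlorophenyl group lowers the number further. From the compounds shown here alone, it is also open whether a nitrile or methoxy in place of the methyl keeps the number near that of compound 2.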